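This account rests on a few compounds, and the source may have more. Where it says the series, first, only, none or still open, it means among the compounds named here.

Measured in a functional assay on BAEC cells (Bos taurus) for antiproliferative activity, read by cell counting, with a stated time of 4 days; a lower number here means a stronger inhibitor, a higher number a weaker inhibitor:
Compound 1 `CCOC(=O)CN(Cc1cc(F)cc(F)c1)c1ccc2c(c1)N(C)CC(C)(COc1ccc(C#N)cc1)O2`: > 100000 nM (a limit)
Compound 2 `CCOC(=O)CN(Cc1cccc(F)c1)c1ccc2c(c1)N(C)CC(C)(COc1ccc(C(=N)N)cc1)O2`: 3900 nM

Among the measured compounds shown here, compound 2, at 3900 nM, holds the only actual number in this assay. Compound 1 gives > 100000 nM, which is a limit of the assay and not a number. Compound 3 `CCOC(=O)CN(Cc1cccc(F)c1)c1ccc2c(c1)N(C)CC(C)(COc1ccc(C#N)cc1)O2` departs from compound 2 in one place, on an aromatic carbon, para to a large group: a group of 2 heavy atoms (1 carbon, 1 nitrogen; no ring) in place of a group of 3 heavy atoms (1 carbon, 2 nitrogen; no ring), on an aromatic carbon. For the measured compounds named here, no measured step isolates this change. Compound 3 shares the cyano group with compound 1, whose reading is the limit > 100000 nM. A large move towards weaker inhibition is expected, an estimated 15-fold higher number from compound 2 to compound 3 (1.19 log units; beyond the scatter). Compound 3 is estimated at 60000 nM, with an expected range of 15000 nM to 100000 nM.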

Compound 3, half-maximal inhibitory concentration: > 100000 nM
Compound 3: a limit, no number; the forecaster's own chance of this, stated with the estimate: 65%; middle value at least 1.6-fold (0.22 log units) away from the limit.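

In this assay, replacing the group of 3 heavy atoms on this aromatic carbon, para to a large group, with cyano gives an at least 25-fold higher number from compound 2 to compound 3 (1.40 log units; beyond the scatter). Compound 3 gives > 100000 nM, a limit of the assay and not a number, so this step has a lower bound but no exact size: the limit of > 100000 nM in this assay, at which 2 of the 3 values shown sit. The step from compound 1 to compound 3, with hydrogen in place of fluoro, cannot be read. The compounds shown leave open whether an amine or a carboxylic acid on this carbon would give a measurable number, and whether the second fluoro matters when the group of compound 2 is present.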